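The source may hold more compounds than are shown below. What is called first, only, known or untested is meant among the compounds shown, and "the series" means these compounds.

Three compounds of this series have been run in a functional assay on ECV-304 cells (Homo sapiens), read by MTT assay, with stated times of 24 h and 12 h, tested at 12.5 uM; a higher number here means a stronger effect of the compound at the concentration tested, a lower number a weaker effect. Compound 1 `COC(=O)c1ccc(OCc2nc(C)c(C)nc2C)c(OC)c1` gives 14.9% and stands highest of the three numbers. Compound 2 `Cc1nc(C)c(CNC(=O)CN2CCCC2=O)nc1C` gives -35.8%, and compound 3 `Cc1nc(C)c(COC(=O)CCCC[C@@H]2CCSS2)nc1C` gives -60% in this assay; both lie beyond the scatter below compound 1. Compound 4 `C=CCc1ccc(OCc2nc(C)c(C)nc2C)c(OC)c1` has not yet been measured. Going by the values given here, it differs from compound 1 in one place: allyl in place of methoxycarbonyl on an aromatic carbon The two measured compounds that share only the core of compound 1 give negative numbers, but no step in this assay between measured compounds that differ in one place is available, so the size of this change is uncertain. A small downward step, possibly not beyond the scatter, is expected: a number 6.9 percentage points lower from compound 1 to compound 4 (within the scatter). Compound 4 is estimated to give 8% in this assay, in the range -22% to 38%.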

Compound 4, a percentage reported as activity, at one concentration (the size of the read-out at that concentration, not a potency): 22%
Compound 4: the middle estimate sits 14 percentage points below what was measured, within the range that was stated.
By their numbers in this assay, from the lowest: compound 3; then compound 2; then compounds 1 and 4 (each within the scatter of the next).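

In this assay, going by these compounds alone, the first one-place step reads a number 7.1 percentage points higher from compound 1 to compound 4 (within the scatter). At this aromatic carbon, para to a large group, allyl can therefore replace methoxycarbonyl, and the two hydrogen-bond acceptors leave with it, without a change beyond the scatter. No supporting evidence bears on why this position tolerates the swap. On these data alone, whether a carboxylic acid, an amine or a longer chain at this position would also stay within the scatter of compound 1 remains open. So does whether this step would hold with another group in place of the methoxy group.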